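Notes on the benzyl substituent in this series

The source may report more compounds than this note shows. Statements on the series, on what has been measured and on what is new or still open speak of the compounds shown alone.

Three compounds of the shared core carry measurements in a functional assay on MCF7 cells (Homo sapiens) for antiproliferative activity, read by MTT assay, with a stated time of 72 h; a lower number here means a stronger inhibitor, a higher number a weaker inhibitor. Compound 1 `CCCSc1nc(N/N=C(\C)c2ccc(O)cc2)c2nnn(Cc3ccccc3)c2n1` gives 21600 nM. Compound 2 `CCCSc1nc(N/N=C(\C)c2ccccc2O)c2nnn(Cc3ccc(O)cc3)c2n1` gives 9520 nM. Compound 3 `C/C(=N\Nc1nc(SCc2ccccc2)nc2c1nnn2Cc1ccccc1)c1ccccc1O` gives 950 nM. Compound 2 thus stands second highest of the three numbers: compound 1 sits above it with a gap beyond the scatter, and compound 3 sits below it with a gap that is also beyond the scatter. Going by the values given here, no pair among the three differs in only one place, so none of these gaps can be tied to a single structural change.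

Compound 4 `CCCSc1nc(N/N=C(\C)c2ccccc2O)c2nnn(Cc3ccc(Br)cc3)c2n1` differs from compound 2 by bromo in place of hydroxy on an aromatic carbon, para to a large group. Among the compounds with values here, no measured pair shows this exchange, so the size of the step in this assay has to be judged from the spread of the three known numbers alone. A step of modest size is expected, more likely toward a lower number than a higher one, though it may well stay within the scatter. Compound 4 is estimated at 6500 nM, with a range from 2200 nM to 19000 nM. The step from compound 2 to compound 4 is expected to read a 1.5-fold lower number from compound 2 to compound 4 (0.17 log units; within the scatter).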

Compound 4, half-maximal inhibitory concentration: 15600 nM
Beside the measured number, compound 4's estimate is 2.4-fold (0.38 log units) below it; the range from low to high includes it.
By their numbers in this assay, from the lowest: compound 3; then compounds 2, 4 and 1 (each within the scatter of the next, the first and the last beyond it).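

Going by these compounds alone, compound 2 and compound 4 form the first pair that differs in one place, so the benzyl substituent can now be read on its own in this assay: a 1.6-fold higher number from compound 2 to compound 4 (0.21 log units; within the scatter). Taking 4-hydroxybenzyl to 4-bromobenzyl, on an aromatic carbon para to a large group, removes the hydrogen-bond donor and acceptor counted for hydroxy, yet the two compounds remain within the scatter of each other, so this exchange does not separate them in this assay, and a hydrogen-bond donor at this carbon is not shown to be needed for the read-out at this level. No supporting measurement on hand speaks to what lies behind this result, so the finding stays a plain observation on one pair.

Still open, as far as these compounds go, is whether an amine, a carboxylic acid or a methoxy group on this carbon would give a step beyond the scatter, since hydroxy and bromo alone span only a narrow sample of groups. Also open, from the compounds shown here alone, is whether the same exchange would read alike with the benzyl group on sulfur carried by compound 3 in place of the propyl chain of compound 2 and compound 4.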